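Working notes: from compound 3 to compound 4

The source may hold more compounds than are shown below. What is called first, only, known or untested is meant among the compounds shown, and "the series" means these compounds.

In an ADME assay on MRC5 cells (Homo sapiens) for cytotoxicity, read by fluorescence and resazurin assay, with a stated time of 3 days (a lower number here means that less compound is needed, a higher number that more compound is needed for the effect), compound 3 (`COC(=O)CCc1ccc(S(=O)(=O)n2c(C3(O)C=CC(=O)C=C3)cc3ccccc32)cc1`) gives 280 nM and compound 1 (`COc1ccc(-n2cc(C3(O)C=CC(=O)C=C3)nn2)cc1`) gives 310 nM with the two values within the scatter of each other. For compound 2 (`CC(=O)OC[C@H]1O[C@@H](n2cc(C3(O)C=CC(=O)C=C3)nn2)[C@H](OC(C)=O)[C@@H](OC(C)=O)[C@H]1OC(C)=O`) the reading of > 50000 nM is a limit of the assay and not a number.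

Compound 4 (`CS(=O)(=O)c1ccc(S(=O)(=O)n2c(C3(O)C=CC(=O)C=C3)cc3ccccc32)cc1`) carries methylsulfonyl in place of 2-(methoxycarbonyl)ethyl on an aromatic carbon, para to a large group (methylsulfonyl in place of 2-(methoxycarbonyl)ethyl on an aromatic carbon). Among the compounds with values here, no measured pair differs in one place only, so this change has no direct precedent. No step beyond the scatter is expected in this assay. The expectation rests on compound 3 at 280 nM and compound 1 at 310 nM which carry different groups on the shared core and still read alike. Compound 2 goes against this pattern, so the range is kept wide. The estimated step is a 1.1-fold higher number from compound 3 to compound 4 (0.03 log units; within the scatter) and it is expected to stay within the scatter. The estimate for compound 4 is 300 nM with an expected range from 120 nM to 800 nM for the coming measurement.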

Compound 4, half-maximal effective concentration: 39 nM
Estimate against measurement, compound 4: 7.7-fold (0.89 log units) above; measured number below the stated range.
By their numbers in this assay, from the lowest: compound 4; then compounds 3 and 1 (each within the scatter of the next). At a limit, above all of these: compound 2.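

In this assay, within the data shown here, the aromatic carbon para to a large group responds to substitution: methylsulfonyl in place of 2-(methoxycarbonyl)ethyl gives a 7.2-fold lower number from compound 3 to compound 4 (0.86 log units; beyond the scatter), the first step between compounds that differ in one place. Compound 1 and compound 3 differ in more than one place, so their matching values say nothing about this position. The count of hydrogen-bond acceptors is the same in the two groups, and nothing measured here accounts for the step.

Still open, as far as these compounds go, is whether the lower number goes with the loss of 2-(methoxycarbonyl)ethyl or with the arrival of methylsulfonyl. A carboxylic acid, an amine or a longer chain on this same carbon would help to separate the two readings.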